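Methoxy position shift on the phenyl in a weak series

The source may hold more compounds than are shown below. What is called first, only, known or untested is meant among the compounds shown, and "the series" means these compounds.

Among the measured compounds shown here, compound 2 `COc1cccc(Cc2nn(C[C@H]3CCCN3C)c(=O)c3ccccc23)c1` gives 1580 nM in an assay for binding affinity to Alpha-1A adrenergic receptor (Homo sapiens) (on this read-out higher numbers stand for weaker inhibition and lower numbers for stronger inhibition), the only finite number in the set. Compound 1 `COC(=O)c1ccc(Cc2nn(C[C@H]3CCCN3C)c(=O)c3ccccc23)cc1` reaches only the assay limit of > 1990 nM in this assay, which is a limit and not a number. Compound 3 `COc1ccc(Cc2nn(C[C@H]3CCCN3C)c(=O)c3ccccc23)cc1` is not yet measured; the change is 4-methoxyphenyl in place of 3-methoxyphenyl on a saturated chain carbon bound to an aromatic carbon. For the measured compounds named here, no step between measured compounds is available, so the expectation rests on the weak showing of compound 2 alone. A step of a 1.6-fold higher number from compound 2 to compound 3 (0.20 log units; within the scatter) is expected, small and not beyond the usual scatter, with a real chance that only a limit is returned. For compound 3 the estimate is 2500 nM, between 800 nM and 8000 nM.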

Compound 3, inhibition constant: 126 nM
Compound 3: the middle estimate sits 20-fold (1.30 log units) above what was measured; the whole stated range lies above it.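

In this assay the aryl group on the saturated chain carbon proves sensitive to methoxy placement alone: 4-methoxyphenyl in place of 3-methoxyphenyl gives a 13-fold lower number from compound 2 to compound 3 (1.10 log units; beyond the scatter) with no change in the atoms. Methoxy in place of methoxycarbonyl on the aromatic carbon gives an at least 15-fold lower number from compound 1 to compound 3 (1.19 log units; beyond the scatter) in the same series. That second step rests on a limit, not a number: the limit of > 1990 nM in this assay, at which 1 of the 3 values shown sits. Going by these compounds, whether this gain is specific to methoxy stays open, since 4-ethoxyphenyl, 4-hydroxyphenyl and 4-chlorophenyl do not appear here. The 2-methoxyphenyl isomer is also absent from the compounds shown.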